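Sulfo replacing the phthalimide end of the piperidine chain

The compounds below may be only part of what the source reports. "The series", "measured", "known", "first", "only" and "open" are said of these compounds alone.

Measured so far in a functional assay on HEK293 cells for agonist activity at 5-hydroxytryptamine receptor 4 (Homo sapiens), read by cAMP accumulation; a higher number here means that more compound is needed for the effect, a lower number that less compound is needed:
compound 1 `COc1cc(N)c(Cl)cc1C(=O)NC1CCN(CCCCCO)CC1` 15.9 nM
compound 2 `COc1cc(N)c(Cl)cc1C(=O)NC1CCN(CCCCCCCCO)CC1` 15.9 nM
compound 3 `COc1cc(N)c(Cl)cc1C(=O)NC1CCN(CCCCCCCCN2C(=O)c3ccccc3C2=O)CC1` 3.16 nM

Compound 3 gives the lowest number of the three in this assay. Its nearest neighbours are compound 1 and compound 2, each separated from it by a step beyond the scatter: a 5.0-fold lower number from compound 2 to compound 3 (0.70 log units; beyond the scatter). Lengthening the chain alone did nothing, no change at the digits printed from compound 1 to compound 2 (within the scatter), so the whole gain in the series sits with the group that entered in compound 3.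

Compound 4 `COc1cc(N)c(Cl)cc1C(=O)NC1CCN(CCCCCCCCS(=O)(=O)O)CC1` takes that group away again: a group of 4 heavy atoms (3 oxygen, 1 sulfur; no ring) in place of a group of 11 heavy atoms (8 carbon, 1 nitrogen, 2 oxygen; one five-membered non-aromatic ring with 1 hetero atom, one six-membered aromatic ring of carbon only), on a saturated chain carbon, eight bonds along the chain from an amine nitrogen in a ring. The step from compound 2 to compound 3 is the one that bears directly on this, since it shows what the leaving group contributed on the same chain position; the step from compound 1 to compound 2 shows that the chain itself is neutral. Going by these compounds, nothing measured here shows a sulfo on this series, so what the entering group does is unknown. Removing the group that brought the gain suggests the number should move back toward the level of compound 2, and the expected step is a 9.5-fold higher number from compound 3 to compound 4 (0.98 log units; beyond the scatter). Compound 4 is therefore estimated at 30 nM in this assay, with a range from 8 nM to 120 nM.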

Compound 4, half-maximal effective concentration: 1000 nM
Estimate against measurement, compound 4: 33-fold (1.52 log units) below; the measured number lies above the stated range.
By their numbers in this assay, from the lowest: compound 3; then compounds 1 and 2 (each within the scatter of the next); then compound 4.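

In this assay, the place eight bonds along the chain from an amine nitrogen in a ring proves far from neutral: the sulfo does not return to the level of the hydroxy compound but goes well past it, with a 63-fold higher number from compound 2 to compound 4 (1.80 log units; beyond the scatter) at that same place. Until now, changes at the chain end had left the number flat or lowered it, whereas here the same end carries the largest step in the series, a 320-fold higher number from compound 3 to compound 4 (2.50 log units; beyond the scatter), and the shorter hydroxy compound gives a step of the same size, a 63-fold higher number from compound 1 to compound 4 (1.80 log units; beyond the scatter). Nothing measured alongside these numbers accounts for the steps, so the sulfo's effect stands as an observation without an explanation.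

Open, going by these compounds, is whether a carboxylic acid or a sulfonamide at the same place would stand with compound 4 or nearer the hydroxy compounds, which would show how far the result is specific to the sulfo. Also open, on these data alone, is how much of the phthalimide is needed for the value of compound 3 , 3.16 nM, which a benzamide or a simple phenyl at the chain end would begin to test.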